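A few compounds are considered here, and "the series" means these few. Any claim that something is new, unique, unknown or untested is made for them only; others in the source may bear on it.

Measured compounds:
compound 1 `CCCCOC(=O)NS(=O)(=O)c1sc(CC(C)C)cc1-c1ccc(CN2C(=O)CN(C)C2=O)cc1` gives 68.6 nM in an assay on membranes from uterus for displacement of a labelled ligand from Angiotensin type II receptor (Sus scrofa), with a stated time of 1.5 h; on this read-out lower numbers stand for stronger inhibition and higher numbers for weaker inhibition;
compound 2 `CCCCOC(=O)NS(=O)(=O)c1sc(CC(C)C)cc1-c1ccc(CN2C(=O)CCC2=O)cc1` gives > 10000 nM in this assay, a limit of the assay rather than a number;
compound 3 `CCCCOC(=O)NS(=O)(=O)c1sc(CC(C)C)cc1-c1ccc(C(=O)c2ccnn2C)cc1` gives 3.4 nM in this assay.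

Of the two numbers shown, compound 3 stands lowest, with compound 1 next at a 20-fold lower number from compound 1 to compound 3 (1.30 log units; beyond the scatter) when read from compound 1 to compound 3. Compound 4 `CCCCOC(=O)NS(=O)(=O)c1sc(CC(C)C)cc1-c1ccc(Cn2cnc(C(F)(F)F)c2)cc1` differs from compound 3 at the same spot on the shared core: a group of 10 heavy atoms (5 carbon, 2 nitrogen, 3 fluorine; one five-membered aromatic ring with 2 hetero atoms) in place of a group of 8 heavy atoms (5 carbon, 2 nitrogen, 1 oxygen; one five-membered aromatic ring with 2 hetero atoms), on an aromatic carbon. For the measured compounds named here, two measured steps touch this position. The change from compound 1 to compound 3 gave a 20-fold lower number from compound 1 to compound 3 (1.30 log units; beyond the scatter), and the change from compound 2 to compound 3 gave an at least 2900-fold lower number from compound 2 to compound 3 (3.46 log units; beyond the scatter), so swapping the group on this aromatic carbon has moved the number a great deal in both known cases. Compound 4 keeps a five-membered aromatic ring but on a saturated chain carbon, as in compounds 1 and 2, which both gave weaker binding than compound 3. A step toward a higher number is therefore expected, a 12-fold higher number from compound 3 to compound 4 (1.07 log units; beyond the scatter), without confidence in its size. Compound 4 is estimated at 40 nM, between 5 nM and 400 nM.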

Compound 4, inhibition constant: 7.3 nM
The estimate for compound 4 lay 5.5-fold (0.74 log units) above the measured number; measured number inside the range.
By their numbers in this assay, from the lowest: compound 3; then compound 4; then compound 1. At a limit, above all of these: compound 2.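

In this assay, 4-(trifluoromethyl)-1H-imidazol-1-yl on a saturated chain carbon gives a 2.1-fold higher number from compound 3 to compound 4 (0.33 log units; beyond the scatter), so a group on that chain carbon can come close to the (1-methyl-1H-pyrazol-5-yl)carbonyl group, which compounds 1 and 2 did not show. The choice of group on that chain carbon also matters greatly, with a 9.4-fold lower number from compound 1 to compound 4 (0.97 log units; beyond the scatter). Compound 2 carries 2,5-dioxopyrrolidin-1-yl there and shows an at least 1300-fold lower number from compound 2 to compound 4 (3.13 log units; beyond the scatter), a step resting on a limit of the assay and not on a number: the limit of > 10000 nM in this assay, at which 1 of the 4 values shown sits.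

From the compounds shown here alone, the change from compound 3 to compound 4 replaces the ring and its link together, so the share of each in this step stays unknown. It is also open whether the trifluoromethyl itself matters, as no compound shown carries a methyl group, a nitrile or a carboxylic acid in its place on the imidazole.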